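Aryl swap on the amide: compound 1 to compound 3

This account rests on a few compounds, and the source may have more. Where it says the series, first, only, none or still open, it means among the compounds named here.

Among the measured compounds shown here, in an ADME assay on microsomes from liver (Homo sapiens) for metabolic stability, with a stated time of 60 min, tested at 10 uM (a higher number here means that more of the compound is left, a lower number that less of the compound is left), compound 1 `CCCS(=O)(=O)N1CCN(C2(CNC(=O)c3ccccc3C(F)(F)F)CCCCC2)CC1` gives 5% and compound 2 `CCCS(=O)(=O)N1CCN(C2(CNC(=O)c3cccc(C(F)(F)F)c3Cl)CCCCC2)CC1` gives 1% as the only other measured value. These two numbers lie within the scatter of each other, so no order can be read between them. Compound 3 `CCCS(=O)(=O)N1CCN(C2(CNC(=O)c3ccc(F)cc3C)CCCCC2)CC1` is still unmeasured. Its change is 4-fluoro-2-methylphenyl in place of 2-(trifluoromethyl)phenyl on a carbonyl carbon and so 4-fluoro-2-methylphenyl stands in place of 2-(trifluoromethyl)phenyl on a carbonyl carbon. For the measured compounds named here, one measured step bears on this, a number 4 percentage points lower from compound 1 to compound 2 (within the scatter) and it changes the group at the same place. Going by the values given here, it is only a loose guide, as no measured compound carries 4-fluoro-2-methylphenyl. The estimated step is a number 1 percentage points higher from compound 1 to compound 3 (within the scatter) and no step beyond the scatter is expected in this assay for this change. For compound 3 the expected value is 6% with an estimated range from 1% to 20%.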

Compound 3, percent of the compound remaining: 2%
Beside the measured number, compound 3's estimate is 4 percentage points above it; low and high end bracket the measured number.
By their numbers in this assay, from the lowest: compounds 2, 3 and 1 (each within the scatter of the next).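

In this assay, a third aryl group on the carbonyl carbon gives a number 3 percentage points lower from compound 1 to compound 3 (within the scatter) and a number 1 percentage points higher from compound 2 to compound 3 (within the scatter) in the comparison with the second aryl swap. Compound 3 carries 4-fluoro-2-methylphenyl and no trifluoromethyl group, yet it separates from neither compound 1 nor compound 2, so at this position the presence of trifluoromethyl is not needed for a number in this range. No measurement at hand offers an explanation for this flat result.

Open, as far as these compounds go, is whether any group on this carbonyl carbon can lift the number beyond the scatter, for example an aryl group bearing a carboxylic acid or an amine. Also open, from the compounds shown here alone, is whether a change elsewhere, such as a shorter chain on the sulfonyl group, would do so.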